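Moving a Trifluoromethyl Group on the Urea Phenyl Ring

A few compounds are considered here, and "the series" means these few. Any claim that something is new, unique, unknown or untested is made for them only; others in the source may bear on it.

Of the compounds shown here, two have been measured in a functional assay on HCC 2998 cells (Homo sapiens) for inhibition, read by sulforhodamine B assay, with a stated time of 48 h, tested at 10 uM; on this read-out higher numbers stand for a weaker effect at the one concentration tested and lower numbers for a stronger effect. Compound 1 `COc1cc2cc(Oc3ccc(NC(=O)Nc4ccccc4)cc3)c(C)nc2cc1OC` gives 105% in this assay. Compound 2 `COc1cc2cc(Oc3ccc(NC(=O)Nc4ccc(C(F)(F)F)cc4)cc3)c(C)nc2cc1OC` carries a trifluoromethyl group where compound 1 carries hydrogen. In this assay compound 2 gives 94.8%. Within the data shown here, the single measured step is a number 10.2 percentage points lower from compound 1 to compound 2 (beyond the scatter). Compound 2 therefore stands lowest of the two numbers, with compound 1 as its nearest neighbour.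

Compound 3 `COc1cc2cc(Oc3ccc(NC(=O)Nc4cccc(C(F)(F)F)c4)cc3)c(C)nc2cc1OC` differs from compound 2 by 3-(trifluoromethyl)phenyl in place of 4-(trifluoromethyl)phenyl on an amide-type nitrogen. Among the measured compounds shown here, the only measured step, from compound 1 to compound 2, concerns the arrival of a trifluoromethyl group in place of hydrogen, not a change from 4-(trifluoromethyl)phenyl to 3-(trifluoromethyl)phenyl; no measured pair compares those two groups. That step thus bears only loosely on the present change, and with no direct comparison the expected step in this assay is a number 0.2 percentage points higher from compound 2 to compound 3 (within the scatter), which does not go beyond the scatter. Compound 3 is estimated to give 95% in this assay, with an expected range from 80% to 110%.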

Compound 3, a percentage reported as activity, at one concentration (the size of the read-out at that concentration, not a potency): 25.4%
For compound 3 the middle estimate is 69.6 percentage points above the measured one; the measured number lies below the stated range.
By their numbers in this assay, from the lowest: compound 3; then compound 2; then compound 1.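

In this assay, moving the trifluoromethyl group around the urea phenyl ring changes the result far more than the earlier step suggested: 3-(trifluoromethyl)phenyl in place of 4-(trifluoromethyl)phenyl gives a number 69.4 percentage points lower from compound 2 to compound 3 (beyond the scatter), although the two groups have the same atoms and the rest of the molecule is unchanged. The same swap of hydrogen for trifluoromethyl therefore has two very different outcomes depending on where the group sits on this ring: it is modest in a number 10.2 percentage points lower from compound 1 to compound 2 (beyond the scatter) and large in a number 79.6 percentage points lower from compound 1 to compound 3 (beyond the scatter), so what matters here is the placement of the group and not merely its presence. No measurement is available that explains why this placement gives so much stronger an effect on these cells.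

The compounds shown leave open whether the strong effect belongs to trifluoromethyl itself or would also appear with a chlorine atom, a methoxy group or a nitrile on the phenyl ring in the place it occupies in compound 3. They also leave open whether a second substituent, such as a fluorine atom added to the 3-(trifluoromethyl)phenyl ring, would strengthen or weaken the effect.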